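A few compounds are considered here, and "the series" means these few. Any claim that something is new, unique, unknown or untested is made for them only; others in the source may bear on it.

The measured compounds in a functional assay on CHO cells for antagonist activity at Orexin/Hypocretin receptor type 1 (Homo sapiens), read by FLIPR and calcium flux; a higher number here means a more potent compound, by a factor of ten per unit of this negative logarithm, a lower number a less potent compound:
compound 1, `Cc1ccc(-n2nccn2)c(C(=O)N2CC3(CC3)C[C@H]2CNc2ccc(Cl)cn2)c1`, gives 8.1
compound 2, `O=C(c1cc(Cl)ccc1-c1ncccn1)N1CC2(CC2)C[C@H]1CNc1cc(C(F)(F)F)ccn1`, gives 8.1
compound 3, `Cc1ccc(-c2ncccn2)c(C(=O)N2CC3(CC3)C[C@H]2CNc2cc(C(F)(F)F)ccn2)c1`, gives 7.3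

Compound 3 stands lowest of the three; compound 1 and compound 2 both sit beyond the scatter above it. For the measured compounds named here, the one single-point step on record is a number 0.80 log units lower from compound 2 to compound 3 (beyond the scatter), and it concerns the substituent on the benzamide ring, not the part changed here.

Compound 4, `Cc1ccc(-c2ncccn2)c(C(=O)N2CC3(CC3)C[C@H]2CNc2ccc(Cl)cn2)c1`, differs from compound 3 in one place: 5-chloropyridin-2-yl in place of 4-(trifluoromethyl)pyridin-2-yl on an amine nitrogen. Going by the values given here, no measured pair isolates this exchange. Compound 1 carries the same 5-chloropyridin-2-yl group and gives 8.1, but it also differs from compound 3 in the aryl substituent, so its value does not settle the matter. Among the compounds with values here, with no step bearing directly on the change, the expectation for this assay is a shift of uncertain direction, likely small; the estimated step is a number 0.40 log units higher from compound 3 to compound 4 (beyond the scatter). Compound 4 is therefore expected to give 7.7, in the range 7.1 to 8.3.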

Compound 4, negative logarithm of the antagonist equilibrium constant: 8.2
For compound 4 the middle estimate is 0.50 log units below the measured one, within the range that was stated.
By their numbers in this assay, from the lowest: compound 3; then compounds 1, 2 and 4 (each within the scatter of the next).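

In this assay, the exchange of 4-(trifluoromethyl)pyridin-2-yl for 5-chloropyridin-2-yl on the amine nitrogen is now isolated, and it is a number 0.90 log units higher from compound 3 to compound 4 (beyond the scatter) so the group at this position clearly matters. With 5-chloropyridin-2-yl in place, pyrimidin-2-yl in place of 2H-1,2,3-triazol-2-yl on an aromatic carbon is a number 0.10 log units higher from compound 1 to compound 4 (within the scatter) so these two rings cannot be told apart here. Nothing at hand explains the size of the first step.

This exchange alters both the substituent and where it stands on the pyridine, so 5-(trifluoromethyl)pyridin-2-yl or 4-chloropyridin-2-yl on the same nitrogen would be needed to separate the two. Also open, going by these compounds, is whether the step of a number 0.80 log units lower from compound 2 to compound 3 (beyond the scatter) would recur with 5-chloropyridin-2-yl on the amine nitrogen.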